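Swapping One Ring Group on a Weak Inhibitor

The source may report more compounds than this note shows. Statements on the series, on what has been measured and on what is new or still open speak of the compounds shown alone.

Two related compounds have been measured in a functional assay on HOS-TE85 cells (Homo sapiens) for inhibition, read by CCK-8 assay, with a stated time of 72 h; a higher number here means a weaker inhibitor, a lower number a stronger inhibitor. Compound 1 `O=C(NCCCCn1cccn1)c1cccc(C2SCC(=O)N2c2cc(Br)ccn2)c1` gives 105 nM.

Compound 2 `CC(C)(C)c1conc1N1C(=O)CSC1c1cccc(C(=O)NCCCCc2ccccc2)c1` gives > 1000 nM, and this value is a limit of the assay, not a number.

Compound 1 and compound 2 differ in more than one place, so their two values do not show what any single change does.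

Compound 3 `O=C(NCCCCc1ccccc1)c1cccc(C2SCC(=O)N2c2ccc(-c3ccccc3)cc2)c1` has not yet been measured. It keeps the rest of compound 2 but changes one group, on an amide-type nitrogen in a ring: a group of 12 heavy atoms (12 carbon; 2 six-membered aromatic rings of carbon only) in place of a group of 9 heavy atoms (7 carbon, 1 nitrogen, 1 oxygen; one five-membered aromatic ring with 2 hetero atoms), on an amide-type nitrogen in a ring. Here 4-phenylphenyl enters, and the five-membered aromatic ring with 2 hetero atoms leaves.

Among the measured compounds shown here, no measured pair gives the size of such a swap, so in this assay no step beyond the scatter is expected. This expectation rests on compound 2, whose limit of > 1000 nM is the nearest guide. The expected change is a step that the limit leaves unreadable from compound 2 to compound 3.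

For compound 3 the estimate is 1500 nM, with an expected range from 400 nM to 6000 nM.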

Compound 3, half-maximal inhibitory concentration: > 1000 nM
Compound 3 ended at the assay's limit (the forecaster's own chance of this, stated with the estimate: 45%); the middle value is on the limit's open side.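

No step can be read between compound 2 and compound 3, because both values are limits and not numbers: the limit of > 1000 nM in this assay, at which 2 of the 3 values shown sit.

The compounds shown leave open how strongly either one really inhibits in this assay, and so whether 4-phenylphenyl, in place of the five-membered aromatic ring with 2 hetero atoms, strengthens inhibition, weakens it or leaves it unchanged.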